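Cyano to fluoro on the enone chain of a chalcone-like core

A few compounds are considered here, and "the series" means these few. Any claim that something is new, unique, unknown or untested is made for them only; others in the source may bear on it.

Compound 2, `COc1ccc(/C=C(\C#N)C(=O)c2cc(OC)c(OC)c(OC)c2)cc1Br`, was tested in an ADME assay on K562 cells (Homo sapiens) for cytotoxicity, read by MTT assay, with a stated time of 5 days; a higher number here means a weaker inhibitor, a lower number a stronger inhibitor; it is recorded there only as a limit of the assay, > 10000 nM. Compound 1, `COc1ccc(/C=C(\C#N)C(=O)c2cc(OC)c(OC)c(OC)c2)c(F)c1`, is likewise recorded only as a limit in this assay, > 10000 nM. Within the data shown here, the single measured step, a step that the two limits leave unreadable from compound 1 to compound 2, therefore cannot be sized, and the sole piece of evidence is the limit of > 10000 nM in this assay, at which 2 of the 2 values shown sit. Compound 3, `COc1ccc(/C=C(\F)C(=O)c2cc(OC)c(OC)c(OC)c2)cc1Br`, differs from compound 2 by fluoro in place of cyano on a double-bonded chain carbon bound to a carbonyl carbon and a double-bonded chain carbon. Among the measured compounds shown here, no measured step touches this position, so nothing in the data speaks for or against a change beyond the scatter. With both measured compounds sitting at the limit, the expected step that the limit leaves unreadable from compound 2 to compound 3 from compound 2 to compound 3 is no more than an estimate. Compound 3 is accordingly expected to give about 15000 nM in this assay, with a range from 4000 nM to 60000 nM, and most likely to be reported again only as a limit.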

Compound 3, half-maximal inhibitory concentration: 6000 nM
Beside the measured number, compound 3's estimate is 2.5-fold (0.40 log units) above it; low and high end bracket the measured number.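

In this assay, fluoro in place of cyano on a double-bonded chain carbon bound to a carbonyl carbon and a double-bonded chain carbon gives an at least 1.6-fold lower number from compound 2 to compound 3 (0.22 log units; that floor lies within the scatter). Compound 3 is thus the only compound shown with a number rather than a limit, and this position is the first at which a change can be read at all, though only as a floor that does not clear the scatter. The other values stay at the limit of the assay: the limit of > 10000 nM in this assay, at which 2 of the 3 values shown sit.

Going by these compounds, the true size of this step remains open, and the step from compound 1 to compound 2 cannot be read. Also open, on these data alone, is whether fluoro behaves alike with the 2-fluoro-4-methoxyphenyl of compound 1, and how an amine or a carboxylic acid would fare on this chain carbon.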